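Adding a Methoxy Group to Compound 2

The source may report more compounds than this note shows. Statements on the series, on what has been measured and on what is new or still open speak of the compounds shown alone.

Compound 1 `COc1cccc(/C=C/C(=O)Nc2cc(OC)c(OC)c(OC)c2)c1`: 44100 nM
Compound 2 `C=C(Br)C(=O)Nc1cccc(/C=C/C(=O)Nc2cc(OC)cc(OC)c2)c1`: 3600 nM

In a functional assay on HT-29 cells (Homo sapiens) for inhibition, read by MTT assay, with a stated time of 72 h (a higher number here means a weaker inhibitor, a lower number a stronger inhibitor), compound 2 holds the lower of the two numbers at 3600 nM, and the gap up to compound 1 lies beyond the scatter. Compound 3 `C=C(Br)C(=O)Nc1cccc(/C=C/C(=O)Nc2cc(OC)c(OC)c(OC)c2)c1` has methoxy in place of hydrogen on an aromatic carbon of compound 2 (methoxy in place of hydrogen on an aromatic carbon). Going by the values given here, no measured pair isolates this change, so no step beyond the scatter is expected in this assay. The expected outcome is a 1.3-fold lower number from compound 2 to compound 3 (0.11 log units; within the scatter). Compound 3 is estimated at 2800 nM, with an expected range of 700 nM to 10000 nM.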

Compound 3, half-maximal inhibitory concentration: 2300 nM
The estimate for compound 3 lay 1.2-fold (0.09 log units) above the measured number; low and high end bracket the measured number.
By their numbers in this assay, from the lowest: compounds 3 and 2 (each within the scatter of the next); then compound 1.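

In this assay methoxy in place of hydrogen, ortho to two methoxy groups and para to a large group, gives a 1.6-fold lower number from compound 2 to compound 3 (0.19 log units; within the scatter) and so leaves the number at this position within the scatter. The large step comes from the other place, where ((1-bromoethenyl)carbonyl)amino in place of methoxy gives a 19-fold lower number from compound 1 to compound 3 (1.28 log units; beyond the scatter) and separates compound 3 clearly from compound 1. Nothing measured here speaks to the reason for either step. From the compounds shown here alone, whether a hydroxyl, an amine or an ethoxy group at this position would fit the same reading stays open. So does whether a plain acetylamino group could stand in for ((1-bromoethenyl)carbonyl)amino and keep the large step.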